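This account rests on a few compounds, and the source may have more. Where it says the series, first, only, none or still open, it means among the compounds named here.

Values in a functional assay on A549 cells (Homo sapiens) for inhibition, read by sulforhodamine B assay, with a stated time of 48 h; a lower number here means a stronger inhibitor, a higher number a weaker inhibitor:
- compound 1 `CCO[C@H]1C[C@@H](c2coc3ccc(Br)cc3c2=O)N(c2ccccc2)O1`: 21500 nM
- compound 2 `O=c1c([C@@H]2C[C@H](c3ccccc3)ON2c2ccccc2)coc2cc(Cl)c(Cl)cc12`: 43000 nM
- compound 3 `O=C1[C@H]2[C@H](ON(c3ccccc3)[C@@H]2c2coc3ccc(Br)cc3c2=O)C(=O)N1c1ccccc1`: 17000 nM

Compound 2 gives the highest of the three numbers in this assay. Compound 1 sits within the usual scatter of it, so no order between those two can be read; compound 3 sits beyond the scatter, with the lower number.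

Compound 4 `CCO[C@H]1C[C@@H](c2coc3cc(Cl)c(Cl)cc3c2=O)N(c2ccccc2)O1` is not yet measured. It differs from compound 2 in one place: ethoxy in place of phenyl on a saturated ring carbon. Going by the values given here, the core of compound 4 is that of compound 2, while the ethoxy group is the one found in compound 1. Among the compounds with values here, no measured pair isolates this single change, so the step has to be judged from compound 1 against compound 2 alone, whose numbers differ only within the scatter.

Compound 4 is expected to land close to compound 1 and to compound 2, with the step of a 1.7-fold lower number from compound 2 to compound 4 (0.24 log units; within the scatter) estimated to stay within the scatter, tending if anything toward a lower number. The estimate for compound 4 in this assay is 25000 nM, with a range from 10000 nM to 60000 nM.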

Compound 4, half-maximal inhibitory concentration: 19800 nM
Beside the measured number, compound 4's estimate is 1.3-fold (0.10 log units) above it, and the stated range covers the measured number.
By their numbers in this assay, from the lowest: compounds 3, 4, 1 and 2 (each within the scatter of the next, the first and the last beyond it).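

In this assay, going by these compounds alone, ethoxy in place of phenyl on the saturated ring carbon next to the ring oxygen gives a 2.2-fold lower number from compound 2 to compound 4 (0.34 log units; beyond the scatter), the first single-change step that can be read. The step is modest, but it shows that the phenyl group at this position is not needed to keep this level of inhibition, and that the ethoxy group, with no ring and fewer heavy atoms, gives the lower number on this core. No measurement at hand accounts for the step.

A single pair cannot separate a contribution of the ethoxy group from the removal of the phenyl group, and a methoxy group, a longer alkoxy chain or an amine at this position would test that. From the compounds shown here alone, whether the step carries over to the core of compound 1 also remains open.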